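The source may report more compounds than this note shows. Statements on the series, on what has been measured and on what is new or still open speak of the compounds shown alone.

Compound 1 `CC(=O)OCCc1c(C)nc(Cl)nc1Cl` in a functional assay on MCF7 cells (Homo sapiens) for antiproliferative activity, read by MTT assay, with a stated time of 24 h; on this read-out higher numbers stand for weaker inhibition and lower numbers for stronger inhibition: > 100000 nM
Compound 2 `COc1nc(Cl)nc(C)c1CCOC(C)=O` in this assay: > 100000 nM

In this assay compound 1 gives only a limit, > 100000 nM. Compound 2 likewise returns a limit, > 100000 nM. The step that the two limits leave unreadable from compound 1 to compound 2 is therefore unreadable, since both values sit at the limit of > 100000 nM in this assay, at which 2 of the 2 values shown sit. Compound 3 `Cc1nc(Cl)nc(Cl)c1CCCl` differs from compound 1 by chloro in place of acetoxy on a saturated chain carbon, two bonds along the chain from an aromatic carbon. For the measured compounds named here, no measured step bears on this change, and compound 1 itself gives no number to build on. Compound 3 is expected to stay near the same limit, a step that the limit leaves unreadable from compound 1 to compound 3 of no readable size. The estimate for compound 3 is 150000 nM, with a range from 30000 nM to 1000000 nM.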

Compound 3, half-maximal inhibitory concentration: 8000 nM
Estimate against measurement, compound 3: 19-fold (1.27 log units) above, and the stated range ends above it.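

In this assay the series shows an at least 12-fold lower number from compound 1 to compound 3 (1.09 log units; beyond the scatter) with chloro in place of acetoxy on a saturated chain carbon, two bonds along the chain from an aromatic carbon. The step from compound 1 to compound 2 cannot be read, so this chain position gives the first readable change. Compound 3 is the only compound shown that gives a number rather than a limit: the limit of > 100000 nM in this assay, at which 2 of the 3 values shown sit.

Still open, as far as these compounds go, is whether the change depends on chloro itself or on the loss of acetoxy. A hydroxyl, an amine or a longer chain ending in chloro at this place would separate the two.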